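Thiophen-2-yl to ethynyl, repeated on a second core

The source may hold more compounds than are shown below. What is called first, only, known or untested is meant among the compounds shown, and "the series" means these compounds.

Compound 1 `Cc1nc(N)c2c(-c3cccs3)cn([C@@H]3O[C@H](CO)[C@@H](O)[C@H]3O)c2n1` gives in an ADME assay on MRC5 cells (Homo sapiens), read by MTT assay, with a stated time of 72 h (on this read-out higher numbers stand for weaker inhibition and lower numbers for stronger inhibition), a value of > 100000 nM, which is a limit of the assay rather than a number.
Compound 2 `COc1nc(N)nc2c1c(-c1cccs1)cn2[C@@H]1O[C@H](CO)[C@@H](O)[C@H]1O` gives in this assay a value of > 100000 nM, again a limit of the assay.
Compound 3 `C#Cc1cn([C@@H]2O[C@H](CO)[C@@H](O)[C@H]2O)c2nc(C)nc(N)c12` gives in this assay a value of > 100000 nM, also a limit of the assay.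

Compound 1 and compound 3 differ in one place only: ethynyl in place of thiophen-2-yl on an aromatic carbon. The step between them, a step that the two limits leave unreadable from compound 1 to compound 3, has no readable size because both values sit at the limit of > 100000 nM in this assay, at which 3 of the 3 values shown sit. Compound 2 carries a different core from compound 1; the difference between the two cores is not broken down here.

Compound 4 `C#Cc1cn([C@@H]2O[C@H](CO)[C@@H](O)[C@H]2O)c2nc(N)nc(OC)c12` is the one not yet measured. It differs from compound 2 by ethynyl in place of thiophen-2-yl on an aromatic carbon, and since the surroundings of the place match word for word, this is the same change that was made from compound 1 to compound 3.

No size can be taken from the earlier step, so the expectation rests on the values themselves. It rests on compound 3, whose value > 100000 nM is a limit. It rests likewise on compound 2, whose value > 100000 nM is a limit. Compound 4 is therefore expected to come out near 150000 nM, most likely again reported only as a limit. The expected step, a step that the limit leaves unreadable from compound 2 to compound 4, would then itself stay unreadable.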

Compound 4, half-maximal inhibitory concentration: > 100000 nM
Compound 4 was reported as a limit (the forecaster's own chance of this, stated with the estimate: 90%); the middle value does not contradict the limit.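

No size can be read for the step between compound 2 and compound 4, because both compounds, like the other two shown, give only a limit rather than a number: the limit of > 100000 nM in this assay, at which 4 of the 4 values shown sit.

The compounds shown leave open whether ethynyl in place of thiophen-2-yl changes the result in this assay at all, and if it does, in which direction and by how much on either core.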